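Replacing a methoxy group on a shared triazine core

The source may hold more compounds than are shown below. What is called first, only, known or untested is meant among the compounds shown, and "the series" means these compounds.

Of the compounds shown here, three sharing one core have been measured in a functional assay on L5178Y cells (Mus musculus); on this read-out lower numbers stand for lower potency and higher numbers for higher potency (the scale is a negative logarithm). Compound 1 `CC1(C)N=C(N)N=C(N)N1c1cccc(F)c1` gives 5.24, compound 2 `CC1(C)N=C(N)N=C(N)N1c1cccc(OCCOc2ccccc2)c1` gives 5.02, and compound 3 `COc1cccc(OCc2cccc(N3C(N)=NC(N)=NC3(C)C)c2)c1` gives 5.36. Compound 3 thus carries the highest of the three numbers; its gap to compound 1 lies within the usual scatter, while its gap to compound 2 lies beyond it.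

Compound 4 `CC1(C)N=C(N)N=C(N)N1c1cccc(COc2cccc(NC(=N)S)c2)c1` has not yet been measured in this assay. It differs from compound 3 in one place: a group of 4 heavy atoms (1 carbon, 2 nitrogen, 1 sulfur; no ring) in place of a group of 2 heavy atoms (1 carbon, 1 oxygen; no ring), on an aromatic carbon. The methoxy group leaves and a group of four heavy atoms with three hydrogen-bond donors enters on an aromatic carbon of a six-membered aromatic ring of carbon only.

Within the data shown here, no pair of measured compounds differs in just one place, so no measured step guides this change. From compound 3 to compound 4 the step is expected to be small, most likely within the scatter, with a slight lean downward: a number 0.16 log units lower from compound 3 to compound 4 (within the scatter). Compound 4 is estimated at 5.2, in a range from 4.7 to 5.8.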

Compound 4, logarithm of the reciprocal of the active concentration, log(1/C): 4.01
Compound 4: middle estimate off by 1.19 log units, on the high side; the measured number lies below the stated range.
By their numbers in this assay, from the lowest: compound 4; then compounds 2, 1 and 3 (each within the scatter of the next, the first and the last beyond it).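

Among these compounds, this aromatic carbon, meta to a large group, is not indifferent to what it carries: in this assay the exchange of methoxy for the group of 4 heavy atoms gives a number 1.35 log units lower from compound 3 to compound 4 (beyond the scatter) and is the only single-place step in the set. Among the compounds shown here, the earlier compounds varied only in groups elsewhere and held no such step, so this one exchange is the first sign that the number can fall sharply through a change at this place. Nothing at hand bears on why the number falls here.

The compounds shown leave open whether the fall belongs to the entering group as a whole or to one part of it. An amine, a thiol or a urea on this same aromatic carbon would tell those readings apart.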